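A few compounds are considered here, and "the series" means these few. Any claim that something is new, unique, unknown or untested is made for them only; others in the source may bear on it.

Compound 2, `COc1cc(NC(C)CCCNC(=O)OC(C)(C)C)c2nc(C(F)(F)F)cc(C)c2c1-c1ccc(C(F)(F)F)cc1`, serves as the starting point. In an ADME assay on RAW264.7 cells (Mus musculus) for cytotoxicity, read by MTT assay, with a stated time of 24 h (a higher number here means a weaker inhibitor, a lower number a stronger inhibitor), compound 2 gives > 48 ug/mL, which is a limit of the assay rather than a number. Among the measured compounds shown here, its neighbour compound 1, `COc1cc(NC(C)CCCNC(=O)OC(C)(C)C)c2nc(C(F)(F)F)cc(C)c2c1-c1cccc(C(F)(F)F)c1`, is the only other measured compound, and in this assay compound 1 gives > 48 ug/mL, likewise a limit. For the measured compounds named here, the one measured step, a step that the two limits leave unreadable from compound 1 to compound 2, therefore cannot be read in size or direction, and the whole measured record amounts to the limit of > 48 ug/mL in this assay, at which 2 of the 2 values shown sit.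

The step to compound 3, `COc1cccc(-c2c(OC)cc(NC(C)CCCNC(=O)OC(C)(C)C)c3nc(C(F)(F)F)cc(C)c23)c1`, is 3-methoxyphenyl in place of 4-(trifluoromethyl)phenyl on an aromatic carbon. Going by the values given here, no measured step touches this kind of exchange, so the expectation rests only on the fact that both measured compounds sit at the limit of this assay. It is therefore expected that the step from compound 2 to compound 3 remains within the scatter, giving a number no higher from compound 2 to compound 3 (the limit leaves the size open), with no change beyond the scatter in either direction.

Compound 3 is accordingly estimated to reach about 48 ug/mL in this assay, in the range from 25 ug/mL to 100 ug/mL, most probably reported again only as a limit.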

Compound 3, half-maximal inhibitory concentration: > 80.2 ug/mL
Compound 3: only a limit was reported (the forecaster's own chance of this, stated with the estimate: 75%); at least 1.6-fold (0.22 log units) between middle value and limit.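

In this assay compound 3 gives > 80.2 ug/mL, which is again a limit of the assay and not a number. The steps to compound 3 from compound 1 and from compound 2 therefore cannot be read in size or direction. The compounds shown leave open whether any of these exchanges on the aromatic carbon changes the cytotoxicity read-out at all.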